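A Switch of the Amino Acid Arm at the Amine

The source may report more compounds than this note shows. Statements on the series, on what has been measured and on what is new or still open speak of the compounds shown alone.

Three compounds share one core and differ only in the amino acid attached to an amine nitrogen. Compound 1 `CC[C@H](C)[C@@H](NCC(=O)NNC(=O)COc1ccc(-c2nc3ccccc3s2)cc1OC)C(=O)O` gives 1790 nM in a functional assay on MCF7 cells (Homo sapiens) for inhibition, read by MTT assay, with a stated time of 3 days; a lower number here means a stronger inhibitor, a higher number a weaker inhibitor. Compound 2 `COc1cc(-c2nc3ccccc3s2)ccc1OCC(=O)NNC(=O)CN[C@@H](CS)C(=O)O` gives 1230 nM in this assay, and compound 3 `COc1cc(-c2nc3ccccc3s2)ccc1OCC(=O)NNC(=O)CN[C@@H](CCSC)C(=O)O` gives 1950 nM in this assay. Compound 1 stands second highest of these three numbers, its nearest neighbour being compound 3 and its furthest compound 2, and all three sit within the scatter of one another. The steps say the same: a 1.5-fold lower number from compound 1 to compound 2 (0.16 log units; within the scatter), a 1.1-fold higher number from compound 1 to compound 3 (0.04 log units; within the scatter) and a 1.6-fold higher number from compound 2 to compound 3 (0.20 log units; within the scatter).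

Compound 4 `CCOC(=O)[C@H](CCSC)NCC(=O)NNC(=O)COc1ccc(-c2nc3ccccc3s2)cc1OC` has not yet been measured in this assay. It differs from compound 1 as follows: 1-(ethoxycarbonyl)-3-(methylsulfanyl)propyl in place of 1-carboxy-2-methylbutyl on an amine nitrogen. The step from compound 1 to compound 3 bears most directly on this change, since the 1-carboxy-3-(methylsulfanyl)propyl arm is kept and only the acid becomes an ethoxycarbonyl group; that step was a 1.1-fold higher number from compound 1 to compound 3 (0.04 log units; within the scatter). Among the measured compounds shown here, no measured pair shows what the ester in place of the acid does, so nothing beyond the scatter is expected, a 1.0-fold higher number from compound 1 to compound 4 (0.00 log units; within the scatter). Compound 4 is therefore expected to give about 1800 nM in this assay, within a range from 800 nM to 4000 nM.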

Compound 4, half-maximal inhibitory concentration: 1760 nM
The estimate for compound 4 lay 1.0-fold (0.01 log units) above the measured number; measured number inside the range.
By their numbers in this assay, from the lowest: compounds 2, 4, 1 and 3 (each within the scatter of the next).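

Among the compounds shown here, compound 4 brings the first change at the acid itself, ethyl in place of hydrogen on an oxygen next to a carbonyl group, and this step stays within the scatter in this assay (a 1.1-fold lower number from compound 3 to compound 4 (0.04 log units; within the scatter)), so in this one arm, capping the acid as an ester gives no measurable change. The two wider swaps on the amine nitrogen also stay within the scatter (a 1.0-fold lower number from compound 1 to compound 4 (0.01 log units; within the scatter); a 1.4-fold higher number from compound 2 to compound 4 (0.16 log units; within the scatter)), which means that all four arms shown, whether they end in a carboxylic acid or an ethoxycarbonyl group, give numbers that cannot be told apart in this assay. Nothing measured here offers an explanation for this flat picture.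

On these data alone, only the 3-(methylsulfanyl)propyl arm appears as an ester, so it remains open whether an ethoxycarbonyl group would leave the numbers just as unchanged on the 2-methylbutyl or 2-sulfanylethyl arms. Also open, as far as these compounds go, is whether an arm carrying a basic amine, a phenyl ring or a much longer chain, or a primary amide in place of the ester, would move the number beyond the scatter.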